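A thiophene amide in place of a dimethylphenyl amide

A few compounds are considered here, and "the series" means these few. Any claim that something is new, unique, unknown or untested is made for them only; others in the source may bear on it.

Measured compounds:
compound 1 `Cc1ccc(C(=O)N[C@H]2CCN(Cc3ccc(OCCCN(C)C)cc3)C2)cc1C` — < 10000 nM
compound 2 `CN(C)CCCOc1ccc(CN2CC[C@H](NC(=O)c3ccc(-c4ccccc4)cc3)C2)cc1` — < 10000 nM

Compound 1 `Cc1ccc(C(=O)N[C@H]2CCN(Cc3ccc(OCCCN(C)C)cc3)C2)cc1C` and compound 2 `CN(C)CCCOc1ccc(CN2CC[C@H](NC(=O)c3ccc(-c4ccccc4)cc3)C2)cc1` share the same core and differ only in the group on the carbonyl of the amide. In an assay on HEK293 cells for binding affinity to Urotensin-2 receptor (Homo sapiens), read by radioligand binding (a higher number here means a weaker inhibitor, a lower number a stronger inhibitor), compound 1 gives < 10000 nM, which is a limit of the assay and not a number. Compound 2 gives < 10000 nM in this assay, again a limit. Compound 1 therefore stands only on a bound, and both values shown sit at the limit of < 10000 nM in this assay, at which 2 of the 2 values shown sit; nothing separates the two compounds on the numbers.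

Compound 3 `CN(C)CCCOc1ccc(CN2CC[C@H](NC(=O)c3cccs3)C2)cc1` differs from compound 1 in one place: thiophen-2-yl in place of 3,4-dimethylphenyl on a carbonyl carbon — thiophen-2-yl in place of 3,4-dimethylphenyl on a carbonyl carbon whose other neighbour is an amide-type nitrogen. Among the measured compounds shown here, no step between measured compounds is available, so the numbers give no size for such a change. The expected step is a step that the limit leaves unreadable from compound 1 to compound 3, nothing beyond the usual scatter. Compound 3 is estimated at 3000 nM in this assay, within 300 nM to 10000 nM, and a limit rather than a number is the more likely report.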

Compound 3, inhibition constant: < 10000 nM
Compound 3: a limit, no number; the forecaster's own chance of this, stated with the estimate: 70%; the middle value is on the limit's open side.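

Compound 3, like compound 1, stands only on a limit and not a number in this assay, so the step between these two compounds cannot be read: the limit of < 10000 nM in this assay, at which 3 of the 3 values shown sit.

The compounds shown leave open where each one truly lies relative to that limit, and whether thiophen-2-yl or 3,4-dimethylphenyl on the carbonyl carbon gives the stronger inhibitor.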